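Swapping one aryl group on a weakly active core

This account rests on a few compounds, and the source may have more. Where it says the series, first, only, none or still open, it means among the compounds named here.

- compound 1 `COc1ccc(-c2nc3cccc(-c4cc(OC)c(OC)c(OC)c4)c3o2)cc1OC`: > 25000 nM (a limit)
- compound 2 `COc1ccc(-c2nc3c(-c4cc(OC)c(OC)c(OC)c4)cccc3o2)cc1OC`: 8900 nM
- compound 3 `COc1cc(OC)cc(-c2nc3c(-c4cc(OC)c(OC)c(OC)c4)cccc3o2)c1`: 5700 nM

All three compounds were tested in a functional assay on NCI-H460 cells (Homo sapiens) for antiproliferative activity, read by MTT assay, with a stated time of 48 h; a higher number here means a weaker inhibitor, a lower number a stronger inhibitor. Compound 1 gives only a limit, > 25000 nM, and not a number. Compound 3 stands at 5700 nM and compound 2 at 8900 nM, and these two values lie within the scatter of each other.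

Compound 4 `COc1ccc(-c2nc3c(-c4cc(OC)c(OC)c(OC)c4)cccc3o2)cc1F` keeps the core of compound 3 and carries 3-fluoro-4-methoxyphenyl in place of 3,5-dimethoxyphenyl on an aromatic carbon. Among the compounds with values here, one measured step bears on this swap, because it also exchanges one substituted phenyl for another: a 1.6-fold lower number from compound 2 to compound 3 (0.19 log units; within the scatter). That step stayed within the scatter, so no change beyond the scatter is expected in this assay, though a single step is thin support. The expected step is a 1.1-fold higher number from compound 3 to compound 4 (0.06 log units; within the scatter). The estimate for compound 4 is 6500 nM, with an expected range from 2800 nM to 15000 nM.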

Compound 4, half-maximal inhibitory concentration: 19900 nM
The estimate for compound 4 lay 3.1-fold (0.49 log units) below the measured number; measured number above the stated range.
By their numbers in this assay, from the lowest: compounds 3 and 2 (each within the scatter of the next); then compound 4. At a limit, above all of these: compound 1.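

At this position, next to the ring nitrogen and the ring oxygen, the choice of substituted phenyl does change the result in this assay: 3-fluoro-4-methoxyphenyl in place of 3,5-dimethoxyphenyl gives a 3.5-fold higher number from compound 3 to compound 4 (0.54 log units; beyond the scatter), whereas the earlier swap between the two dimethoxyphenyl groups stayed within the scatter. Within the data shown here, the single change of fluoro in place of methoxy points the same way, with a 2.2-fold higher number from compound 2 to compound 4 (0.35 log units; beyond the scatter), so this fluoro compound is modestly weaker than either dimethoxyphenyl compound. Nothing shown here accounts for this loss of activity.

Among these compounds, with only one fluoro compound in the set, it remains open whether fluoro in place of methoxy would have the same result on other phenyl groups. Going by these compounds, it also remains open whether an amine or a hydroxyl group on this phenyl ring would bring the number lower than that of compound 3.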